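Trifluoromethoxy for trifluoromethyl on a second core

The compounds below may be only part of what the source reports. "The series", "measured", "known", "first", "only" and "open" are said of these compounds alone.

The account concerns four urea-linked piperidine amides measured in a physicochemical assay for lipophilicity, read by HPLC, with a stated time of 90 min, tested at 100 uM; a higher number here means a more lipophilic compound, a lower number a more polar compound. Compound 1 `Cc1ccoc1C(=O)N1CCC(NC(=O)Nc2ccc(C(F)(F)F)cc2)CC1` gives 4.29. Compound 2 `Cc1ccoc1C(=O)N1CCC(NC(=O)Nc2ccc(OC(F)(F)F)cc2)CC1` carries the change trifluoromethoxy in place of trifluoromethyl on an aromatic carbon and gives 4.48. The step of a number 0.19 log units higher from compound 1 to compound 2 (within the scatter) is small and lies within the scatter of the method.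

Compound 3 `CC(C)C(=O)N1CCC(NC(=O)Nc2ccc(C(F)(F)F)c(F)c2)CC1` rests on a different core; in this assay compound 3 gives 4.4. The difference between the core of compound 1 and the core of compound 3 is not broken down here.

Compound 4 `CC(C)C(=O)N1CCC(NC(=O)Nc2ccc(OC(F)(F)F)c(F)c2)CC1` has not yet been measured. It stands to compound 3 as compound 2 stands to compound 1, carrying the change (trifluoromethoxy in place of trifluoromethyl on an aromatic carbon). The surroundings are not identical: in compound 4 the site is also ortho to a fluoro group, so this is the same kind of change rather than the same change. Within the data shown here, the one earlier example of it is the step between compound 1 and compound 2, and that example is the only basis available for an expectation.

The step from compound 3 to compound 4 in this assay is therefore expected to be a number 0.19 log units higher from compound 3 to compound 4 (within the scatter), because a number 0.19 log units higher from compound 1 to compound 2 (within the scatter) was observed for the matching pair. Compound 4 is estimated to give 4.59 in this assay, with a range from 4.35 to 4.85.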

Compound 4, partition coefficient: 4.73
Compound 4: middle estimate off by 0.14 log units, on the low side; low and high end bracket the measured number.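

Across the two cores the change moves the number the same way: in this assay it gives a number 0.33 log units higher from compound 3 to compound 4 (beyond the scatter), and on the other core it gave a number 0.19 log units higher from compound 1 to compound 2 (within the scatter), so the direction is shared, although only the newer step lies beyond the scatter. This is a modest result that rests on just two matched pairs, and it does not show that the size of the step is fixed from one core to another, nor that the direction would hold on any further core; the two cores differ in more than one place, and only in compound 4 does the trifluoromethoxy group sit ortho to a fluoro group, so the contribution of that fluoro group cannot be separated from that of the rest of the core. Nothing shown here bears on why the step comes out as it does.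

The compounds shown leave open whether the step would keep its direction on a core carrying an amine or a carboxylic acid, or a longer chain on the amide. They also leave open how the same change would read with a chloro or methoxy group standing in place of the fluoro group.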